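A few compounds are considered here, and "the series" means these few. Any claim that something is new, unique, unknown or untested is made for them only; others in the source may bear on it.

In a functional assay on B16 cells (Mus musculus) for cytotoxicity, read by CCK-8 assay, with a stated time of 24 h (a higher number here means a weaker inhibitor, a lower number a stronger inhibitor), compound 1 (`COc1ccccc1Oc1c(N)nc(Cc2ccccc2)nc1OCCO`) gives 47400 nM and compound 2 (`COc1ccccc1Oc1c(N)nc(-c2cccc(C)c2)nc1OCCO`) gives 70900 nM on the same core. Compound 3 (`COc1ccccc1Oc1c(N)nc(-c2ccc(C)cc2)nc1OCCO`) gives 8430 nM and holds the lowest of these three numbers. Compound 4 (`COc1ccc(-c2nc(N)c(Oc3ccccc3OC)c(OCCO)n2)cc1`) differs from compound 3 in a single group, with methoxy in place of methyl on an aromatic carbon. For the measured compounds named here, no measured step changes this group itself. The closest evidence is an 8.4-fold lower number from compound 2 to compound 3 (0.92 log units; beyond the scatter) when the methyl group changes place, alongside a 5.6-fold lower number from compound 1 to compound 3 (0.75 log units; beyond the scatter) and a 1.5-fold higher number from compound 1 to compound 2 (0.17 log units; within the scatter) for the other changes. These steps are modest or smaller, so the expected change is small, namely a 1.4-fold higher number from compound 3 to compound 4 (0.15 log units; within the scatter) with only a slight lean in direction. The estimated value for compound 4 is 12000 nM (expected range 4000 nM to 40000 nM).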

Compound 4, half-maximal inhibitory concentration: 18100 nM
Compound 4: middle estimate off by 1.5-fold (0.18 log units), on the low side; the measured number falls inside the stated range.
By their numbers in this assay, from the lowest: compound 3; then compound 4; then compounds 1 and 2 (each within the scatter of the next).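

In this assay, for the compounds shown here, replacing methyl with methoxy on the aromatic carbon para to a large group is the first change that keeps the phenyl link and the substituent's place, and it gives a 2.1-fold higher number from compound 3 to compound 4 (0.33 log units; beyond the scatter). The 4-methoxyphenyl group still keeps its number lower than the other two groups do, with a 3.9-fold lower number from compound 2 to compound 4 (0.59 log units; beyond the scatter) and a 2.6-fold lower number from compound 1 to compound 4 (0.42 log units; beyond the scatter), so only part of the advantage of 4-methylphenyl is lost. Nothing measured here explains this shift. The compounds shown leave open how an amine, a chlorine or a carboxylic acid at this carbon would compare. They also leave open whether a longer chain such as ethoxy would continue the shift seen with methoxy.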